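A few compounds are considered here, and "the series" means these few. Any claim that something is new, unique, unknown or untested is made for them only; others in the source may bear on it.

Compound 1 `CC(=O)c1ccc(-c2ccc(N3CCCC3)nn2)cc1`: > 25000 nM
Compound 2 `COc1ccc(Nc2ccc(-c3ccccc3)nn2)cc1`: > 25000 nM
Compound 3 `CCN(CC)c1ccc(-c2ccc(C(C)=O)cc2)nn1`: > 25000 nM

These results come from a functional assay on PC-3 cells (Homo sapiens) for antiproliferative activity, with a stated time of 48 h (on this read-out higher numbers stand for weaker inhibition and lower numbers for stronger inhibition), and each is a limit of the assay, not a number. Taken together they give one picture: the limit of > 25000 nM in this assay, at which 3 of the 3 values shown sit. Compound 3 is therefore known only as a limit, > 25000 nM.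

Compound 4 `CCN(CC)c1ccc(-c2ccc(C(=O)O)cc2)nn1` has hydroxy in place of methyl on a carbonyl carbon, which turns acetyl into carboxy (hydroxy in place of methyl on a carbonyl carbon). Going by the values given here, the only measured step is a step that the two limits leave unreadable from compound 1 to compound 3. It concerns a different place in the structure and has no readable size. Starting from compound 3 at > 25000 nM, no shift beyond the scatter is expected in this assay, in either direction. The expected change is a step that the limit leaves unreadable from compound 3 to compound 4. Compound 4 is estimated at 30000 nM, with an expected range of 10000 nM to 100000 nM.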

Compound 4, half-maximal inhibitory concentration: > 25000 nM
Compound 4 was reported as a limit (the forecaster's own chance of this, stated with the estimate: 85%); the middle value lies beyond the limit too.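

Compound 3 and compound 4 are both known only as limits, so the change from acetyl to carboxy gives no readable step: the limit of > 25000 nM in this assay, at which 4 of the 4 values shown sit.

The compounds shown leave open whether any change to the shared core gives a readable value in this assay.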